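A few compounds are considered here, and "the series" means these few. Any claim that something is new, unique, unknown or untested is made for them only; others in the source may bear on it.

Working notes on the series.

Three compounds of the shared core have been run in an ADME assay on the whole organism for inhibition, with Echinochloa crus-galli var. formosensis as the target, with a stated time of 4 days; on this read-out higher numbers stand for weaker inhibition and lower numbers for stronger inhibition. Compound 1 `CCN(c1nc(Cl)nc(N[C@@H](C)c2ccccc2)n1)C(C)C` gives 229 nM and stands at the lowest number of the three. Compound 2 `CCNc1nc(Cl)nc(NC(C)c2ccccc2)n1` gives 9770 nM, and compound 3 `CCN(CC)c1nc(Cl)nc(N[C@H](C)c2ccccc2)n1` gives 24000 nM. For the measured compounds named here, both gaps from compound 1 are beyond the usual scatter, so compound 1 is the strongest inhibitor among the compounds measured so far. Going by the values given here, no single-point step between any two of these measured compounds is available: compound 2 and compound 3 differ from compound 1 in more than one place, and their numbers can be read only as a whole.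

The next compound to be measured is compound 4 `CCCCNc1nc(Cl)nc(N[C@@H](C)c2ccccc2)n1`. Its change from compound 1 is butylamino in place of ethyl(isopropyl)amino on an aromatic carbon. The group that leaves carries no hydrogen-bond donor; the group that enters carries one, as counted above, and is the shorter by one heavy atom.

Among the compounds with values here, compound 4 is expected to come out weaker than compound 1 in this assay, a step of an 8.7-fold higher number from compound 1 to compound 4 (0.94 log units; beyond the scatter), because compound 2 gives 9770 nM as the only compound carrying a single alkyl on that nitrogen, while compound 1 gives 229 nM. The estimate for compound 4 is 2000 nM, with a range from 400 nM to 10000 nM.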

Compound 4, half-maximal inhibitory concentration: 12900 nM
Beside the measured number, compound 4's estimate is 6.5-fold (0.81 log units) below it, outside the stated range (above it).
By their numbers in this assay, from the lowest: compound 1; then compounds 2, 4 and 3 (each within the scatter of the next, the first and the last beyond it).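

Butylamino in place of ethyl(isopropyl)amino on an aromatic carbon gives a 56-fold higher number from compound 1 to compound 4 (1.75 log units; beyond the scatter) in this assay, the first change at this position that can be read with the rest of the shared core held fixed. It shows that inhibition in this read-out depends strongly on the group at this position, which lies between two ring nitrogen atoms and opposite the ring nitrogen, but this one step changes several things at once: the entering group carries a hydrogen-bond donor, the leaving group carries none, and the count goes from 6 heavy atoms to 5 heavy atoms. No measurement at hand accounts for the size of this step.

The compounds shown do not separate the hydrogen-bond donor from the shape of the chain, and butyl(ethyl)amino, which keeps the butyl chain on a nitrogen without a hydrogen-bond donor, would bear directly on that question. Also open, on these data alone, is how isopropylamino, which keeps the isopropyl group and carries a hydrogen-bond donor, would read against compound 1 in this assay.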